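The source may report more compounds than this note shows. Statements on the series, on what has been measured and on what is new or still open speak of the compounds shown alone.

Measured so far in a functional assay on the whole organism (strain albino) for inhibition, with Rattus norvegicus as the target, read by paw edema, with stated times of 30 min and 2 h, at a dose of 0.28 mmol/kg by the oral route; on this read-out higher numbers stand for more inhibition at the one dose given (going by the name of the read-out) and lower numbers for less inhibition:

compound 1 `COc1ccc(-c2nnc(SCC(=O)Nc3ccc(/C(C)=N/O)cc3)n2-c2ccccc2)cc1` gives 56%
compound 2 `C=CCn1c(SCC(=O)Nc2ccc(C(C)=O)cc2)nnc1-c1ccc(OC)c(OC)c1` gives 57%
compound 3 `C=CCn1c(SCC(=O)Nc2ccc(/C(C)=N/O)cc2)nnc1-c1ccc(OC)c(OC)c1` gives 56%

Compound 2 has the highest number of the three, but both other values lie within the scatter of it, so no ordering among them can be claimed. Going by the values given here, the one step measured between compounds that differ in a single place is that a number 1 percentage points lower from compound 2 to compound 3 (within the scatter), and it concerns the group on the far ring, not the part that changes here.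

Compound 4 `C=CCn1c(SCC(=O)Nc2ccc(C(C)=O)cc2)nnc1-c1ccc(OC)cc1` is compound 2 with one alteration: hydrogen in place of methoxy on an aromatic carbon. Among the compounds with values here, no measured pair isolates this change. Compound 1 and compound 3 carry one methoxy and two methoxy groups on that ring but differ elsewhere too, and their two values are equal. Nothing seen so far points to a shift beyond the scatter, so the step expected in this assay is a number 1 percentage points lower from compound 2 to compound 4 (within the scatter). Compound 4 is therefore estimated at 56%, with a range of 46% to 66%.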

Compound 4, a percentage reported as inhibition, in the whole organism at one dose (the size of the read-out at that dose, not a potency): 51%
Beside the measured number, compound 4's estimate is 5 percentage points above it; the measured number falls inside the stated range.
By their numbers in this assay, from the lowest: compounds 4, 1, 3 and 2 (each within the scatter of the next).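

In this assay, replacing 3,4-dimethoxyphenyl with 4-methoxyphenyl gives a number 6 percentage points lower from compound 2 to compound 4 (within the scatter). Going by these compounds alone, this is the first pair in which the methoxy group is the only difference, so its contribution can now be read directly rather than inferred from compounds that also differ elsewhere. On this pair, the read-out does not separate the compound with that methoxy group from the one with hydrogen in its place, and no measurement is available to explain the size of the step.

From the compounds shown here alone, it remains open whether a hydroxyl group, an amine or a carboxylic acid on this aromatic carbon would give a step beyond the scatter. Going by these compounds, it is also open whether hydrogen in place of methoxy would give a similar step from compound 3, which differs from compound 2 in the group on the far ring.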